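Nitro Group Replaces Difluoro Pattern on the Carbonyl Arm

This account rests on a few compounds, and the source may have more. Where it says the series, first, only, none or still open, it means among the compounds named here.

Among the compounds with values here, compound 2 `CN(C(=O)NC(=O)c1ccc(F)c(F)c1)c1nc(C(F)(F)F)c(C(=O)N/N=C/c2cccc(C(F)(F)F)c2)s1` gives 5.6 ug/mL in a functional assay on HepG2 cells (Homo sapiens) for inhibition, read by MTT assay, with a stated time of 72 h (on this read-out higher numbers stand for weaker inhibition and lower numbers for stronger inhibition), the lower of the two numbers measured so far, though its gap to compound 1 lies within the scatter. Compound 1 `CN(C(=O)NC(=O)c1ccc(C(F)(F)F)cc1)c1nc(C(F)(F)F)c(C(=O)N/N=C/c2cccc(C(F)(F)F)c2)s1` gives 7.95 ug/mL, and the step of a 1.4-fold lower number from compound 1 to compound 2 (0.15 log units; within the scatter) is small. Compound 3 `CN(C(=O)NC(=O)c1ccc([N+](=O)[O-])cc1)c1nc(C(F)(F)F)c(C(=O)N/N=C/c2cccc(C(F)(F)F)c2)s1` carries 4-nitrophenyl in place of 3,4-difluorophenyl on a carbonyl carbon. Within the data shown here, only that earlier step, a 1.4-fold lower number from compound 1 to compound 2 (0.15 log units; within the scatter), touches this same carbonyl carbon, and it stayed within the scatter, so for compound 3 no shift beyond the scatter is expected, a 1.1-fold higher number from compound 2 to compound 3 (0.03 log units; within the scatter) in this assay. Compound 3 is therefore estimated at 6 ug/mL, expected between 2.8 ug/mL and 13 ug/mL.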

Compound 3, half-maximal inhibitory concentration: 4.73 ug/mL
Beside the measured number, compound 3's estimate is 1.3-fold (0.10 log units) above it, and the stated range covers the measured number.
By their numbers in this assay, from the lowest: compounds 3, 2 and 1 (each within the scatter of the next).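

Three different phenyl groups on this carbonyl carbon now give numbers in this assay that lie within the scatter of one another: a 1.2-fold lower number from compound 2 to compound 3 (0.07 log units; within the scatter), and a 1.7-fold lower number from compound 1 to compound 3 (0.23 log units; within the scatter). Even the change from 3,4-difluorophenyl, with 0 hydrogen-bond acceptors, to 4-nitrophenyl, with 2, produces no clear shift in the read-out. Nothing available explains this lack of separation. On these data alone, all three compounds carry a phenyl group here, so it remains open whether an amine, a carboxylic acid or a longer chain on that ring would move the number beyond the scatter.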